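Side-chain variation on a shared core: compound 4

The source may report more compounds than this note shows. Statements on the series, on what has been measured and on what is new or still open speak of the compounds shown alone.

Measured so far in an in vitro assay on 293-EBNA cells for binding affinity to corticotropin-releasing factor receptor 1 (Homo sapiens); on this read-out lower numbers stand for stronger inhibition and higher numbers for weaker inhibition:
compound 1, `COCC(COC)N(C)c1nc(C)nc2c1nnn2-c1ccc(C(C)C)cc1Br`, 21.3 nM
compound 2, `CCCCC(CC)Nc1nc(C)nc2c1nnn2-c1ccc(C(C)C)cc1Br`, 3.1 nM
compound 3, `CCC(CO)Nc1nc(C)nc2c1nnn2-c1ccc(C(C)C)cc1Br`, 25.3 nM

Compound 3 gives the highest number of the three. Against compound 1 the gap is a 1.2-fold higher number from compound 1 to compound 3 (0.07 log units; within the scatter), within the scatter; against compound 2 it is an 8.2-fold higher number from compound 2 to compound 3 (0.91 log units; beyond the scatter), beyond it. Compound 4, `CCC(COC)Oc1nc(C)nc2c1nnn2-c1ccc(C(C)C)cc1Br`, changes compound 3 by 1-(methoxymethyl)propoxy in place of (1-(hydroxymethyl)propyl)amino on an aromatic carbon. Within the data shown here, the steps that bear on this are an 8.2-fold higher number from compound 2 to compound 3 (0.91 log units; beyond the scatter) and a 6.9-fold lower number from compound 1 to compound 2 (0.84 log units; beyond the scatter): side chains carrying oxygen sit at the higher numbers, and compound 1, with ether oxygens rather than a hydroxy, lies within the scatter of compound 3. Among the measured compounds shown here, no measured step replaces the ring-bound nitrogen by oxygen, so that part is untested. For compound 4 the expectation is a step of about a 1.0-fold lower number from compound 3 to compound 4 (0.01 log units; within the scatter) in this assay, an estimate of 25 nM, ranging from 8 nM to 80 nM.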

Compound 4, inhibition constant: 1.9 nM
Beside the measured number, compound 4's estimate is 13-fold (1.12 log units) above it; measured number outside the range, below it.
By their numbers in this assay, from the lowest: compounds 4 and 2 (each within the scatter of the next); then compounds 1 and 3 (each within the scatter of the next).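

At this aromatic carbon, a side chain carrying oxygen can reach low numbers in this assay, with a 13-fold lower number from compound 3 to compound 4 (1.12 log units; beyond the scatter) and an 11-fold lower number from compound 1 to compound 4 (1.05 log units; beyond the scatter) as the two large steps. The 1-(methoxymethyl)propoxy chain also matches the (1-ethylpentyl)amino chain within the scatter, with a 1.6-fold lower number from compound 2 to compound 4 (0.21 log units; within the scatter) as the step, so oxygen in the side chain does not by itself give a high number. No evidence at hand accounts for these steps.

On these data alone, the change combines a ring-bound nitrogen going to oxygen with a hydroxy going to a methoxy, and the share of each stays open. Also open, as far as these compounds go, are (1-(methoxymethyl)propyl)amino, 1-(hydroxymethyl)propoxy and a carboxylic acid at the chain end.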